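Sulfonamide series: pyrimidin-2-yl in place of 3-chlorophenyl

The compounds below may be only part of what the source reports. "The series", "measured", "known", "first", "only" and "open" are said of these compounds alone.

Measured so far in a functional assay on HEK293 cells for agonist activity at probable G-protein coupled receptor 27 (Homo sapiens), read by a luciferase reporter and beta-arrestin recruitment, with a stated time of 10 min; a higher number here means that more compound is needed for the effect, a lower number that less compound is needed:
compound 1 `O=C(Nc1ccc(S(=O)(=O)Nc2ccccc2)cc1)c1ccc(Cl)cc1F` gives 3980 nM
compound 2 `O=C(Nc1ccc(S(=O)(=O)Nc2cccc(Cl)c2)cc1)c1ccc(Cl)cc1Cl` gives 575 nM

Compound 2 stands lowest of the two numbers. Compound 1 is the nearest point and sits at a clearly higher number, a gap beyond the usual scatter of repeated runs. Compound 1 and compound 2 differ in more than one place, so no single step can be read from that pair.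

The next compound, compound 3 `O=C(Nc1ccc(S(=O)(=O)Nc2ncccn2)cc1)c1ccc(Cl)cc1Cl`, keeps the whole of compound 2 except the sulfonamide nitrogen, where the change is pyrimidin-2-yl in place of 3-chlorophenyl on a sulfonamide nitrogen. The ring that leaves is carbon only; the ring that enters carries two ring nitrogens.

Within the data shown here, no measured pair in this set isolates a change on the sulfonamide nitrogen, so the size of the coming step has no precedent here. The step from compound 2 to compound 3 in this assay is expected to raise the number by a moderate amount, a 3.1-fold higher number from compound 2 to compound 3 (0.50 log units; beyond the scatter), with a wide spread that does not exclude a result within the scatter.

Compound 3 is therefore estimated at 1800 nM, with a range from 450 nM to 7000 nM in this assay.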

Compound 3, half-maximal effective concentration: > 100000 nM
Compound 3 gave a limit, no number; the forecaster's own chance of this, stated with the estimate: 15%; middle value at least 55-fold (1.74 log units) away from the limit.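

In this assay, among these compounds, the sulfonamide nitrogen is the first place where a single change can be read, and that change is large: pyrimidin-2-yl in place of 3-chlorophenyl gives an at least 170-fold higher number from compound 2 to compound 3 (2.24 log units; beyond the scatter). Compound 1 and compound 2 differ in more than one place, so they could not show how much the outcome depends on this one substituent. The size of the step is a lower bound only, with compound 3 standing at a limit of the assay and not at a number: the limit of > 100000 nM in this assay, at which 1 of the 3 values shown sits.

The step exchanges a carbon-only ring bearing chlorine for a ring carrying two ring nitrogens and no chlorine, so the compounds shown do not separate the loss of the chlorine from the entry of the ring nitrogens. From the compounds shown here alone, a plain phenyl ring or a pyridinyl ring with a single ring nitrogen on the sulfonamide nitrogen, with the rest of compound 2 kept, would divide the step into those two parts, and how far the loss extends across other heteroaryl rings remains open.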